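A few compounds are considered here, and "the series" means these few. Any claim that something is new, unique, unknown or untested is made for them only; others in the source may bear on it.

Measured so far:
compound 1 `CCCCCCCCCCCCCCCCCCNC(=O)[C@H]1CSC(CCCCCCCCCCCC)N1`, which in a functional assay on LNCaP cells (Prostate gland, Homo sapiens) for antiproliferative activity, read by sulforhodamine B assay (a higher number here means a weaker inhibitor, a lower number a stronger inhibitor), gives 11900 nM;
compound 2 `CCCCCCCCCCCCCCCCCCNC(=O)[C@H]1CSC(Cc2ccccc2)N1`, which in this assay gives 4400 nM.

Among the measured compounds shown here, compound 2 stands lowest of the two numbers; the only measured step is a 2.7-fold lower number from compound 1 to compound 2 (0.43 log units; beyond the scatter), a modest one. Compound 3 `CCCCCCCCCCCCCCCCCCNC(=O)[C@H]1CSC(c2ccc(C)cc2)N1` differs from compound 2 by 4-methylphenyl in place of benzyl on a saturated ring carbon. For the measured compounds named here, that earlier step put phenyl in place of undecyl, a different kind of change, so it bears on this one only loosely, and no measured step rejoins the same atoms in this way. A step within the scatter is therefore expected, a 1.3-fold lower number from compound 2 to compound 3 (0.10 log units; within the scatter). Compound 3 is estimated at 3500 nM, between 1500 nM and 8500 nM.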

Compound 3, half-maximal inhibitory concentration: 1900 nM
Compound 3: the middle estimate sits 1.8-fold (0.27 log units) above what was measured; the range from low to high includes it.
By their numbers in this assay, from the lowest: compound 3; then compound 2; then compound 1.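

Benzyl giving way to 4-methylphenyl on the saturated ring carbon, with the same atoms joined differently, gives a 2.3-fold lower number from compound 2 to compound 3 (0.36 log units; beyond the scatter) in this assay and so moves the number beyond the scatter. Dodecyl giving way to 4-methylphenyl at this carbon gives a 6.3-fold lower number from compound 1 to compound 3 (0.80 log units; beyond the scatter) and is the largest step among the three compounds. No measurement offered here explains either step.

As far as these compounds go, whether an amine or a carboxylic acid in place of the methyl of 4-methylphenyl would keep this gain remains open. So does the effect of a shorter chain on the amide nitrogen.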